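The compounds below may be only part of what the source reports. "The series", "measured", "known", "first", "only" and "open" are said of these compounds alone.

Compound 1 `CN(C)c1ccc(C2CC(c3ccc(-n4cncn4)cc3)=NN2)cc1` is one of three compounds whose numbers are known here. In a functional assay on MDA-MB-231 cells (Homo sapiens) for inhibition, read by sulforhodamine B assay, tested at 10 uM (a lower number here means less inhibition, a higher number more inhibition at the concentration tested (going by the name of the read-out)), compound 1 gives 7%, the lowest of the three. Its nearest neighbour is compound 2 `CN(C)c1ccc(C2CC(c3ccc(-n4ccnc4)cc3)=NN2)cc1`, which in this assay gives 7.6%; the two differ by a number 0.6 percentage points higher from compound 1 to compound 2 (within the scatter), so the exchange of ring on the aromatic carbon changes nothing that can be read. Far away stands compound 3 `CN1CCN(c2ccc(C3=NN(S(=O)(=O)c4ccc(C#N)cc4)C(c4ccc(N(C)C)cc4)C3)cc2)CC1`, which in this assay gives 99.8%; it carries a sulfonyl group on the ring nitrogen of the shared core and a different aryl group as well, so no single step connects it to compound 1, and its number can only be set beside that of compound 1 as two values.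

Compound 4 `CN(C)c1ccc(C2CC(c3ccc(-n4cncn4)cc3)=NN2C(=O)c2ccc(F)cc2)cc1` has not yet been measured. It differs from compound 1 in one place: (4-fluorophenyl)carbonyl in place of hydrogen on an amine nitrogen in a ring. Within the data shown here, no measured step covers this change. Among the measured compounds shown here, the only step known, from compound 1 to compound 2, concerns another part of the molecule and was within the scatter. What compound 3 shows, a high number with a substituted ring nitrogen, hints toward an increase but is not a step. Compound 4 is therefore estimated at 45%, in the range 10% to 85%, an expected step of a number 38 percentage points higher from compound 1 to compound 4 (beyond the scatter) with wide uncertainty.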

Compound 4, a percentage reported as inhibition, at one concentration (the size of the read-out at that concentration, not a potency): 12.5%
Compound 4: the middle estimate sits 32.5 percentage points above what was measured, within the range that was stated.
By their numbers in this assay, from the lowest: compounds 1, 2 and 4 (each within the scatter of the next); then compound 3.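

In this assay, the exchange of hydrogen for (4-fluorophenyl)carbonyl on the amine nitrogen in the ring gives a number 5.5 percentage points higher from compound 1 to compound 4 (within the scatter), so no change can be read from this substitution. Among these compounds, this is the first step that reaches this position: the only earlier step concerned the azole ring on the aromatic carbon at the other end of the molecule, and it left this nitrogen untouched. It shows that filling this nitrogen with an aromatic carbonyl group does not by itself carry the number beyond the scatter, and nothing at hand offers an explanation for this result.

The compounds shown leave open whether a different group on this nitrogen, such as an acetyl group, a benzyl group or a longer chain ending in an amine, would give a number that can be told apart from that of compound 1. Compound 3 differs from compound 4 in more than one place, so its number cannot be tied to any single part of its structure, and which of those parts goes with it remains unresolved.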